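This account rests on a few compounds, and the source may have more. Where it says the series, first, only, none or still open, it means among the compounds named here.

Compound 1 `COc1ccc2nc(C)cc(OCC(=O)Nc3cc(C)cc(C)c3)c2c1` gives 20000 nM in a toxicity assay on HepG2 cells (Homo sapiens) for inhibition, read by CellTiter-Glo, with a stated time of 48 h; on this read-out higher numbers stand for weaker inhibition and lower numbers for stronger inhibition. Compound 2 `COc1ccc2nc(C)cc(OCC(=O)Nc3ccccc3)c2c1` gives 39800 nM in this assay. Compound 3 `COc1cccc(NC(=O)COc2cc(C)nc3ccc(OC)cc23)c1` gives only a limit of this assay, > 100000 nM.

Compound 3 therefore stands at the limit of > 100000 nM in this assay, at which 1 of the 3 values shown sits, so its inhibition is the weakest that the numbers can show, and no exact figure for it is known. The change to compound 4 `COc1ccc2nc(C)cc(OCC(=O)Nc3cc(C)ccc3OC)c2c1` is 2-methoxy-5-methylphenyl in place of 3-methoxyphenyl on an amide-type nitrogen: the methoxy stays but moves, and a methyl is added. The measured steps among the three compounds were a 2.0-fold higher number from compound 1 to compound 2 (0.30 log units; within the scatter), an at least 5.0-fold higher number from compound 1 to compound 3 (0.69 log units; beyond the scatter) and an at least 2.5-fold higher number from compound 2 to compound 3 (0.40 log units; beyond the scatter). Every step that brought in a methoxy on the phenyl raised the number beyond the scatter, and compound 1 with two methyl groups gave the lowest number seen. Compound 4 carries both a methoxy and a methyl, so no step beyond the scatter in either direction is expected in this assay, and a limit may again be reported. For compound 4 a value of about 100000 nM is expected, between 40000 nM and 250000 nM. This estimate means a number no higher from compound 3 to compound 4 (the limit leaves the size open).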

Compound 4, half-maximal inhibitory concentration: > 100000 nM
Compound 4: a limit, no number; the forecaster's own chance of this, stated with the estimate: 55%; the middle value sits exactly at the limit.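

Moving the methoxy on the phenyl and adding a methyl, which gives the 2-methoxy-5-methylphenyl on the amide nitrogen, still yields no exact number in this assay: compound 4 gives only a limit, > 100000 nM. So a methyl on the phenyl does not by itself go with a lower number, since this group gives an at least 2.5-fold higher number from compound 2 to compound 4 (0.40 log units; beyond the scatter), and against the 3,5-dimethylphenyl it gives an at least 5.0-fold higher number from compound 1 to compound 4 (0.69 log units; beyond the scatter). The step from compound 3 to compound 4 cannot be read, and the limit now holds both methoxy-bearing compounds: the limit of > 100000 nM in this assay, at which 2 of the 4 values shown sit.

From the compounds shown here alone, the exact numbers behind these two limits stay open, as does the separate share of the methoxy and the methyl in compound 4. Also open, going by these compounds, is how the number would respond to an amine or a carboxylic acid on the phenyl.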